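The compounds below may be only part of what the source reports. "The series", "measured", "known", "first", "only" and "open" are said of these compounds alone.

Three compounds have so far been measured in a toxicity assay on the whole organism (strain Icem-CET (SPF Caw)) for cytotoxicity, with Mus musculus as the target; a lower number here means that less compound is needed, a higher number that more compound is needed for the effect:

compound 1, `C#CCNC(=O)/C(C)=C(\C)c1ccc(Br)cc1`, with 180 mg/kg
compound 2, `C/C(C(=O)NC1CC1)=C(/C)c1ccc(Br)cc1`, with 100 mg/kg
compound 3, `C#CCNC(=O)/C(C)=C(\C)c1cc(OC)c(OC)c(OC)c1`, with 160 mg/kg

Compounds 1 and 2 share one core and differ in a single place: cyclopropyl in place of propargyl on an amide-type nitrogen. In this assay this change gave a 1.8-fold lower number from compound 1 to compound 2 (0.26 log units; within the scatter), so the two numbers sit within the usual scatter of each other and cannot be told apart with confidence. Compound 3 carries a different core; the difference between the two cores is not broken down here. In this assay compound 3 stands close to compound 1, and its gap to compound 2 is also within the scatter.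

Compound 4, `COc1cc(/C(C)=C(\C)C(=O)NC2CC2)cc(OC)c1OC`, has not yet been measured. It stands to compound 3 exactly as compound 2 stands to compound 1: cyclopropyl in place of propargyl on an amide-type nitrogen. The surroundings of the change are the same in both pairs, so this is the same change made on a second core. For the measured compounds named here, because the only earlier example of it gave a 1.8-fold lower number from compound 1 to compound 2 (0.26 log units; within the scatter), compound 4 is expected to return a number close to that of compound 3, if anything a little lower. Compound 4 is therefore estimated at 95 mg/kg, with a likely range from 55 mg/kg to 165 mg/kg. For compound 4 the expected step is a 1.7-fold lower number from compound 3 to compound 4 (0.23 log units; within the scatter), and it rests on a single earlier example, so a second example on a new core could well turn out differently.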

Compound 4, dose for half-maximal effect: 320 mg/kg
For compound 4 the middle estimate is 3.4-fold (0.53 log units) below the measured one; measured number outside the range, above it.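

In this assay, putting cyclopropyl in place of propargyl on the amide-type nitrogen gave a 2.0-fold higher number from compound 3 to compound 4 (0.30 log units; within the scatter), and on its own this step cannot be told apart from no change at all. Set beside the earlier example, however, the same change did not carry over from one core to the other as a fixed shift, since the two steps run in opposite directions and the gap between them is larger than the scatter of two such steps: the same change on two cores in this assay, a 1.8-fold lower number (0.26 log units; within the scatter) from compound 1 to compound 2 and a 2.0-fold higher number (0.30 log units; within the scatter) from compound 3 to compound 4, 3.6-fold (0.56 log units) apart, beyond the scatter of two such steps. For the compounds shown here, this suggests that, in these four compounds, the outcome of the change depends on the core it is made on, but with only one pair on each core it does not show why, and it gives no rule for predicting the outcome on a third core.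

The compounds shown leave open how a different group on the same nitrogen, such as ethyl or a longer chain such as butyl, would behave on either core. No pair shown breaks the difference between the two cores into single changes, so which part of that difference goes with the different outcome remains unknown.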